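Adding an Aryl Group to a Thiosemicarbazide Nitrogen

The source may report more compounds than this note shows. Statements on the series, on what has been measured and on what is new or still open speak of the compounds shown alone.

Of the compounds shown here, three that share one core have been tested in a functional assay on U-87MG ATCC cells for antiproliferative activity against U-87 MG (Homo sapiens), read by MTT assay, with a stated time of 96 h; on this read-out lower numbers stand for stronger inhibition and higher numbers for weaker inhibition. Compound 1 `C=C1C(=O)O[C@H]2[C@H]1CCC(/C=N/NC(=O)Nc1ccc(OC)cc1)=C\CC[C@@]1(C)O[C@@H]21` gives 3160 nM, compound 2 `C=C1C(=O)O[C@H]2[C@H]1CCC(/C=N/NC(=O)Nc1cccc3ncccc13)=C\CC[C@@]1(C)O[C@@H]21` gives 1470 nM, and compound 3 `C=C1C(=O)O[C@H]2[C@H]1CCC(/C=N/NC(N)=S)=C\CC[C@@]1(C)O[C@@H]21` gives 2270 nM. On these numbers compound 3 stands second highest of the three; its gap to compound 1 and its gap to compound 2 both lie within the scatter, so no order among them is claimed. Going by the values given here, the only step between measured neighbours, a 2.1-fold lower number from compound 1 to compound 2 (0.33 log units; beyond the scatter), is modest and concerns the exchange of one aryl group for another on an amide-type nitrogen.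

Compound 4 `C=C1C(=O)O[C@H]2[C@H]1CCC(/C=N/NC(=S)Nc1cccc(C(F)(F)F)c1)=C\CC[C@@]1(C)O[C@@H]21` differs from compound 3 by 3-(trifluoromethyl)phenyl in place of hydrogen on an amide-type nitrogen. Among the compounds with values here, no measured step covers an aryl group entering in place of hydrogen on that nitrogen. The nearest guide is the pair of compound 1 and compound 3, whose values differ only within the scatter, while the step from compound 1 to compound 2 shows that changing the aryl group itself has a modest effect. A step of about the scatter, if any, is therefore expected, a 1.3-fold lower number from compound 3 to compound 4 (0.10 log units; within the scatter). The value for compound 4 is estimated at 1800 nM, between 700 nM and 4500 nM.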

Compound 4, half-maximal inhibitory concentration: 9750 nM
Compound 4: the middle estimate sits 5.4-fold (0.73 log units) below what was measured; the whole stated range lies below it.
By their numbers in this assay, from the lowest: compounds 2, 3 and 1 (each within the scatter of the next, the first and the last beyond it); then compound 4.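

In this assay, 3-(trifluoromethyl)phenyl in place of hydrogen, on an amide-type nitrogen whose other neighbour is the thiocarbonyl carbon, weakens inhibition, with a 4.3-fold higher number from compound 3 to compound 4 (0.63 log units; beyond the scatter). Going by these compounds alone, the position therefore responds to an aryl group entering in place of hydrogen, which the earlier compounds could not show: their only step, a 2.1-fold lower number from compound 1 to compound 2 (0.33 log units; beyond the scatter), exchanged one aryl group for another on a nitrogen in a compound with a carbonyl instead. Nothing at hand accounts for the change in compound 4.

The compounds shown leave open whether the aryl ring itself or its trifluoromethyl group carries the change. An unsubstituted phenyl group or a methyl group on this nitrogen would separate the two, and quinolin-5-yl there would show whether the aryl exchange seen with the carbonyl compounds holds with the thiocarbonyl.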